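Swapping the branched alkyl group on the ring nitrogen

The compounds below may be only part of what the source reports. "The series", "measured", "known", "first", "only" and "open" are said of these compounds alone.

In an assay for binding affinity to Corticotropin releasing factor receptor (Rattus norvegicus) (a higher number here means a weaker inhibitor, a lower number a stronger inhibitor), compound 1, `CCc1nc2c(-c3ccc(OC)nc3C(F)(F)F)ccnc2n1C(C)CC`, gives 0.7 nM. Compound 2, `CCc1nc2c(-c3ccc(OC)nc3C(F)(F)F)ccnc2n1C(CC)C1CC1`, gives 0.7 nM. Compound 3, `CCc1nc2c(-c3ccc(OC)nc3C)ccnc2n1C(CC)C1CC1`, gives 0.7 nM.

Compound 3 thus stands level with compound 1 and compound 2; the three values lie within the scatter of one another. The unmeasured compound 4, `CCc1nc2c(-c3ccc(OC)nc3C)ccnc2n1C(C)C1CCC1`, differs from compound 3 in one place: 1-cyclobutylethyl in place of 1-cyclopropylpropyl on an aromatic nitrogen. The measured step that bears most directly on this change is the earlier exchange at the same chain carbon, no change at the digits printed from compound 1 to compound 2 (within the scatter), which shows that reshaping this saturated substituent left the read-out where it was. The other step, no change at the digits printed from compound 2 to compound 3 (within the scatter), concerns a different part of the molecule and also produced no movement. Both steps point to an exchange at this position that is tolerated without a measurable shift in this assay. Compound 4 is therefore expected to land close to compound 3, with the estimated step of a 1.4-fold higher number from compound 3 to compound 4 (0.15 log units; within the scatter) not beyond the scatter. The estimate for compound 4 is 1 nM, with a range from 0.4 nM to 3 nM.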

Compound 4, inhibition constant: 2.1 nM
Estimate against measurement, compound 4: 2.1-fold (0.32 log units) below; the measured number falls inside the stated range.
By their numbers in this assay, from the lowest: compounds 1, 2 and 3 (each within the scatter of the next); then compound 4.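

In this assay, 1-cyclobutylethyl in place of 1-cyclopropylpropyl on the aromatic nitrogen gives a 3.0-fold higher number from compound 3 to compound 4 (0.48 log units; beyond the scatter), the only step among these compounds that lies beyond the scatter. This position therefore does not accept every exchange without a measurable shift, even though the two groups match in their count of heavy atoms, all carbon, and neither carries a hydrogen-bond donor or acceptor. What they differ in is the three-membered or four-membered ring and the chain that carries it, and nothing shown gives a reason for the shift. The compounds shown leave open whether the ring or the chain accounts for the step, since 1-cyclopropylethyl and 1-cyclobutylpropyl are not among them. They also leave open whether the step would hold with trifluoromethyl in place of methyl on the shared core.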